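The source may report more compounds than this note shows. Statements on the series, on what has been measured and on what is new or still open speak of the compounds shown alone.

Values in an ADME assay on Vero cells (Chlorocebus sabaeus) for cytotoxicity, read by MTT assay, with a stated time of 72 h (on this read-out lower numbers stand for higher toxicity in this test and higher numbers for lower toxicity in this test), as measured, both of them limits of the assay:
- compound 1 `CN(CC1CCCCC1)N1CCN(c2nc(=O)c3cc(C(F)(F)F)cc([N+](=O)[O-])c3s2)CC1` with > 64 ug/mL as a limit
- compound 2 `O=c1nc(N2CCN(NCc3cc(F)cc(F)c3)CC2)sc2c([N+](=O)[O-])cc(C(F)(F)F)cc12` with > 64 ug/mL as a limit

Compound 2 stands at > 64 ug/mL and that entry is a limit, not a number. Compound 1 with > 64 ug/mL is a limit in the same way. For the measured compounds named here, the only measured step reads a step that the two limits leave unreadable from compound 1 to compound 2 and gives no size to carry forward. What bears on the next change is the limit of > 64 ug/mL in this assay, at which 2 of the 2 values shown sit, and no readable number lies behind it.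

The change to compound 3 `COc1ccc(CNN2CCN(c3nc(=O)c4cc(C(F)(F)F)cc([N+](=O)[O-])c4s3)CC2)cc1` is 4-methoxyphenyl in place of 3,5-difluorophenyl on a saturated chain carbon bound to an amine nitrogen and reads in words as 4-methoxyphenyl in place of 3,5-difluorophenyl on a saturated chain carbon bound to an amine nitrogen.

With compound 2 held at the limit > 64 ug/mL as the starting point, no step beyond the scatter is expected in this assay and no direction can be argued. The estimate is a number no higher from compound 2 to compound 3 (the limit leaves the size open) as the expected step. For compound 3 the estimated value is 64 ug/mL with an expected range from 32 ug/mL to 128 ug/mL and a further limit is the likeliest report.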

Compound 3, half-maximal cytotoxic concentration: > 64 ug/mL
Compound 3 gave a limit, no number; the forecaster's own chance of this, stated with the estimate: 85%; the middle value lies on the limit itself.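

In this assay compound 3 gives > 64 ug/mL, a limit and not a number. No step from compound 1 or compound 2 to compound 3 can be read: the limit of > 64 ug/mL in this assay, at which 3 of the 3 values shown sit.

The compounds shown leave open at what concentration any of them becomes cytotoxic in this assay, and whether the groups exchanged among them make any difference to that concentration.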